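The source may hold more compounds than are shown below. What is called first, only, known or untested is meant among the compounds shown, and "the series" means these compounds.

Of the compounds shown here, two sharing one core have so far been measured in a functional assay on LoVo cells (Homo sapiens) for inhibition, read by MTT assay, with a stated time of 72 h (on this read-out lower numbers stand for stronger inhibition and higher numbers for weaker inhibition), and they differ in one place. Compound 1 (`C=C(Br)C(=O)Nc1cccc(/C=C/C(=O)Nc2ccccc2)c1`) has a hydrogen at that place and gives 3900 nM as its value. Compound 2 (`C=C(Br)C(=O)Nc1cccc(/C=C/C(=O)Nc2ccc(OCC)cc2)c1`) has an ethoxy group there instead and gives 850 nM as its value, the lower of the two numbers and so the stronger inhibition. The next compound is compound 3 (`C=C(Br)C(=O)Nc1cccc(/C=C/C(=O)Nc2ccc(SC(F)(F)F)cc2)c1`), where (trifluoromethyl)sulfanyl stands in place of ethoxy on an aromatic carbon ((trifluoromethyl)sulfanyl in place of ethoxy on an aromatic carbon). Going by the values given here, only one measured step bears on this change (a 4.6-fold lower number from compound 1 to compound 2 (0.66 log units; beyond the scatter)), and it is modest but beyond the scatter. Among the compounds with values here, it shows that the number differs when this carbon carries ethoxy rather than hydrogen, yet no measured compound compares ethoxy with another group at that place. No clear direction can therefore be argued, and the expectation in this assay is a step that stays within the scatter. The expected step is small (a 1.1-fold lower number from compound 2 to compound 3 (0.03 log units; within the scatter)) and could in fact go either way. The estimated value for compound 3 is 800 nM (range 250 nM to 2800 nM).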

Compound 3, half-maximal inhibitory concentration: 29300 nM
Beside the measured number, compound 3's estimate is 37-fold (1.56 log units) below it; the whole stated range lies below it.
By their numbers in this assay, from the lowest: compound 2; then compound 1; then compound 3.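

In this assay, the group on this aromatic carbon can matter far more than the first pair suggested: (trifluoromethyl)sulfanyl in place of ethoxy gives a 34-fold higher number from compound 2 to compound 3 (1.54 log units; beyond the scatter) as a large step, even though the two groups are alike in carrying no ring, no net charge and no hydrogen-bond donor. The change from hydrogen also matters, with a 7.5-fold higher number from compound 1 to compound 3 (0.88 log units; beyond the scatter) running in the opposite direction to a 4.6-fold lower number from compound 1 to compound 2 (0.66 log units; beyond the scatter) in this pair of comparisons, so a substituent here can lower or raise the number depending on which group it is. Nothing in the data given explains why these two groups part so widely.

With only hydrogen, ethoxy and (trifluoromethyl)sulfanyl shown at this place, the compounds cannot tell whether the high number goes with the sulfur atom or with the fluorine atoms. Trifluoromethoxy and ethylsulfanyl, each changing one of those features, would separate the two, while an amine, a carboxylic acid or a longer alkoxy chain such as butoxy would show how far the trend set by ethoxy extends.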